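The compounds below may be only part of what the source reports. "The series", "measured", "known", "first", "only" and "open" are said of these compounds alone.

Compound 1 `CCOC(=O)C1=C(C)NC(=S)NC1c1ccc(O)cc1` gives, in a functional assay on HT-29 cells (Homo sapiens) for inhibition, read by sulforhodamine B assay, with a stated time of 48 h (a lower number here means a stronger inhibitor of growth, a higher number a weaker inhibitor of growth), > 250 ug/mL.
Compound 2 `CCOC(=O)C1=C(C)NC(=S)NC1c1ccc(F)cc1` gives, in this assay, 26.5 ug/mL.

For compound 1 the figure is only a limit of the assay (the limit of > 250 ug/mL in this assay, at which 1 of the 2 values shown sits). Among the measured compounds shown here, compound 2 is therefore the only compound with a true number. For the measured compounds named here, the one measured step, an at least 9.4-fold lower number from compound 1 to compound 2 (0.97 log units; beyond the scatter), concerns a different exchange on the same aromatic carbon. Compound 3 `CCCc1ccc(C2NC(=S)NC(C)=C2C(=O)OCC)cc1` differs from compound 2 by propyl in place of fluoro on an aromatic carbon. Going by the values given here, no measured step covers this exchange, so the expectation rests on compound 2 alone. Compound 3 is expected near 22 ug/mL, between 6 ug/mL and 80 ug/mL, a step of a 1.2-fold lower number from compound 2 to compound 3 (0.08 log units; within the scatter) that is expected to stay within the scatter.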

Compound 3, concentration for 50% growth inhibition: 50.4 ug/mL
For compound 3 the middle estimate is 2.3-fold (0.36 log units) below the measured one; measured number inside the range.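

In this assay, the exchange of fluoro for propyl on this aromatic carbon gives a 1.9-fold higher number from compound 2 to compound 3 (0.28 log units; within the scatter), so a small atom and a three-carbon chain are not told apart here. Propyl, like fluoro, also separates from hydroxy, with an at least 4.9-fold lower number from compound 1 to compound 3 (0.69 log units; beyond the scatter). From the compounds shown here alone, the true size of that step stays unknown, because the figure for compound 1 is a limit of the assay: the limit of > 250 ug/mL in this assay, at which 1 of the 3 values shown sits.

Still open, going by these compounds, is whether an amine or a carboxylic acid on this carbon would behave like hydroxy, and whether a longer chain such as hexyl would behave like propyl.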